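Moving the chloroacetamide to the other ring position

The compounds below may be only part of what the source reports. "The series", "measured", "known", "first", "only" and "open" are said of these compounds alone.

Compound 3 `C/C=C/C(=O)Nc1cccc(Cn2nc(-c3ccc(Oc4ccccc4)cc3)cc2C(=O)OCC)c1` gives 14200 nM in a functional assay on Maver1 cells (Homo sapiens) for inhibition, read by luminescence and CellTiter-Glo, with a stated time of 72 h (a higher number here means a weaker inhibitor, a lower number a stronger inhibitor), the highest of the three numbers; compound 2 `C=CC(=O)Nc1ccc(Cn2nc(-c3ccc(Oc4ccccc4)cc3)cc2C(=O)OCC)cc1` gives 13300 nM, and compound 1 `CCOC(=O)c1cc(-c2ccc(Oc3ccccc3)cc2)nn1Cc1cccc(NC(=O)CCl)c1` gives 500 nM. Compound 4 `CCOC(=O)c1cc(-c2ccc(Oc3ccccc3)cc2)nn1Cc1ccc(NC(=O)CCl)cc1` differs from compound 3 by 4-(((chloromethyl)carbonyl)amino)phenyl in place of 3-(((prop-1-en-1-yl)carbonyl)amino)phenyl on a saturated chain carbon bound to an aromatic nitrogen. Among the measured compounds shown here, the steps that bear on this are a 28-fold higher number from compound 1 to compound 3 (1.45 log units; beyond the scatter), which changed only the group on the carbonyl carbon, and a 27-fold higher number from compound 1 to compound 2 (1.42 log units; beyond the scatter), which changed both that group and the ring position, while a 1.1-fold higher number from compound 2 to compound 3 (0.03 log units; within the scatter). Restoring the chloromethyl group is therefore expected to bring a large fall, so compound 4 is estimated at 1500 nM (range 400 nM to 6000 nM), an expected step of a 9.5-fold lower number from compound 3 to compound 4 (0.98 log units; beyond the scatter).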

Compound 4, half-maximal inhibitory concentration: 400 nM
Compound 4: middle estimate off by 3.8-fold (0.57 log units), on the high side; the measured number falls inside the stated range.
By their numbers in this assay, from the lowest: compounds 4 and 1 (each within the scatter of the next); then compounds 2 and 3 (each within the scatter of the next).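

In this assay, chloromethyl in place of vinyl on a carbonyl carbon gives a 33-fold lower number from compound 2 to compound 4 (1.52 log units; beyond the scatter) and shows the same large drop with the group at the 4-position of the phenyl ring. Moving it from 3-(((chloromethyl)carbonyl)amino)phenyl to 4-(((chloromethyl)carbonyl)amino)phenyl gives only a 1.3-fold lower number from compound 1 to compound 4 (0.10 log units; within the scatter) and so leaves the number unchanged within the scatter. The chloromethyl group, not its ring position, therefore tracks a 36-fold lower number from compound 3 to compound 4 (1.55 log units; beyond the scatter) across both changes. Nothing measured here explains this link. Still open, on these data alone, is whether methyl or bromomethyl in place of chloromethyl would give numbers like those of compound 1 and compound 4 or like those of compound 2 and compound 3.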